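Removing a Methoxy Group from a Cyclic Shared Core

The compounds below may be only part of what the source reports. "The series", "measured", "known", "first", "only" and "open" are said of these compounds alone.

Measured compounds:
Compound 1, `COc1ccc2c(c1)C(=O)C(=O)N2CCCCn1cc(COc2cc(=O)oc3ccccc23)nn1`: 48%
Compound 2, `O=C1C(=O)N(CCCCn2cc(COc3cc(=O)oc4ccccc34)nn2)c2ccccc21`: 72%
Compound 3, `COc1ccc2c(c1)C(=O)C(=O)N2CCCn1cc(COc2cc(=O)oc3ccccc23)nn1`: 52%

These three compounds were tested in a functional assay on HCT-116 cells (Homo sapiens) for inhibition, read by sulforhodamine B assay, with a stated time of 48 h, tested at 50 uM; on this read-out lower numbers stand for less inhibition of growth and higher numbers for more inhibition of growth at the one concentration tested. Compound 1 and compound 2 differ in one place only, namely (hydrogen in place of methoxy on an aromatic carbon). This change gives a number 24 percentage points higher from compound 1 to compound 2 (beyond the scatter). Compound 3 shares a core with compound 1, but the difference between the two cores is not broken down here; their values in this assay lie within the scatter of each other.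

Compound 4, `O=C1C(=O)N(CCCn2cc(COc3cc(=O)oc4ccccc34)nn2)c2ccccc21`, has not yet been measured. It differs from compound 3 by hydrogen in place of methoxy on an aromatic carbon. The place described for this change matches word for word the place described for the change from compound 1 to compound 2, so it is the same change made on a different core. It is therefore expected to give a step of similar size, a number 22 percentage points higher from compound 3 to compound 4 (beyond the scatter), resting on the step of a number 24 percentage points higher from compound 1 to compound 2 (beyond the scatter) seen in this assay. On this basis compound 4 is estimated to reach 74%, with a likely range from 60% to 88%.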

Compound 4, percent growth inhibition at one concentration: 79%
For compound 4 the middle estimate is 5 percentage points below the measured one, and the stated range covers the measured number.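

In this assay the swap of methoxy for hydrogen gives a number 27 percentage points higher from compound 3 to compound 4 (beyond the scatter) and so raises growth inhibition on a second core as well. The size of the step carries over from one core to the other, so in this series the change behaves much the same on both: the same change on two cores in this assay, a number 24 percentage points higher (beyond the scatter) from compound 1 to compound 2 and a number 27 percentage points higher (beyond the scatter) from compound 3 to compound 4, 3 percentage points apart, within the scatter of two such steps. For the compounds shown here, this rests on only two matched pairs, read at a single concentration in one cell line, so it neither explains why the compounds without methoxy read higher nor shows that the step would hold on a core that differs more.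

Among the compounds shown, only methoxy and hydrogen appear at this place, so it stays open how a chlorine atom, a hydroxyl group or an amine there would read. From the compounds shown here alone, a longer chain in the core also remains open, as does the question of whether the step would keep its size at other concentrations.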